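The source may report more compounds than this note shows. Statements on the series, on what has been measured and on what is new or still open speak of the compounds shown alone.

Of the compounds shown here, three that share one core have been measured in a functional assay on PC-3 cells (Homo sapiens) for inhibition; on this read-out higher numbers stand for weaker inhibition and lower numbers for stronger inhibition. Compound 1 `Cc1c(C(=O)N/N=C\c2ccc(O)cc2)oc2cccc(O)c12` gives 21700 nM, compound 2 `Cc1c(C(=O)N/N=C\c2cccc(O)c2O)oc2cccc(O)c12` gives 12200 nM, and compound 3 `Cc1c(C(=O)N/N=C\c2cc(F)ccc2O)oc2cccc(O)c12` gives 3170 nM. Among these numbers compound 2 stands second highest: its nearest neighbour is compound 1, with a 1.8-fold lower number from compound 1 to compound 2 (0.25 log units; within the scatter), while its furthest is compound 3, with a 3.8-fold lower number from compound 2 to compound 3 (0.59 log units; beyond the scatter). Compound 4 `Cc1c(C(=O)N/N=C\c2cc(Cl)ccc2O)oc2cccc(O)c12` has not yet been measured and changes compound 2 in one place: 5-chloro-2-hydroxyphenyl in place of 2,3-dihydroxyphenyl on a carbon with a double bond to nitrogen. The step bearing most directly on this is a 3.8-fold lower number from compound 2 to compound 3 (0.59 log units; beyond the scatter), where a 5-fluoro-2-hydroxyphenyl took the same place; a 6.8-fold lower number from compound 1 to compound 3 (0.84 log units; beyond the scatter) points the same way. A step of similar size in this assay is therefore expected, so compound 4 is estimated at 2500 nM, within 900 nM to 7000 nM. That estimate means an expected 4.9-fold lower number from compound 2 to compound 4 (0.69 log units; beyond the scatter).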

Compound 4, half-maximal inhibitory concentration: 3120 nM
Compound 4: middle estimate off by 1.2-fold (0.10 log units), on the low side; the measured number falls inside the stated range.
By their numbers in this assay, from the lowest: compounds 4 and 3 (each within the scatter of the next); then compounds 2 and 1 (each within the scatter of the next).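

The new result shows that the step does not depend on fluoro alone. Chloro at this place also gives a number beyond the scatter from both compounds with other rings (a 3.9-fold lower number from compound 2 to compound 4 (0.59 log units; beyond the scatter); a 7.0-fold lower number from compound 1 to compound 4 (0.84 log units; beyond the scatter)) in this assay. Chloro in place of fluoro makes no readable difference (a 1.0-fold lower number from compound 3 to compound 4 (0.01 log units; within the scatter)). Nothing here explains these results. From the compounds shown here alone, how a methoxy group or an amine in place of the chloro would behave stays open. So does whether the hydroxy of the 5-chloro-2-hydroxyphenyl is needed.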